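This account rests on a few compounds, and the source may have more. Where it says the series, first, only, none or still open, it means among the compounds named here.

Measured compounds:
- compound 1, `CC(Oc1ccccc1-c1ccncc1)C1=NCCN1`: 1450 nM
- compound 2, `CC(Oc1ccccc1-c1ccccc1[N+](=O)[O-])C1=NCCN1`: 1230 nM
- compound 3, `CC(Nc1ccccc1-c1ccccc1)C1=NCCN1`: 708 nM

The three compounds were tested in an assay on CHO cells for displacement of a labelled ligand from Alpha-2C adrenergic receptor (Homo sapiens); a lower number here means a stronger inhibitor, a higher number a weaker inhibitor. In this assay compound 2 gives 1230 nM, the second highest of the three numbers. Its nearest neighbour is compound 1, which in this assay gives 1450 nM, a gap that lies within the scatter. Furthest from it is compound 3, which in this assay gives 708 nM, yet this gap too lies within the scatter, so the three numbers cannot be ordered with confidence.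

Compound 4, `Cc1ccccc1-c1ccccc1OC(C)C1=NCCN1`, has not been measured. It differs from compound 2 by the change (methyl in place of nitro on an aromatic carbon), that is, methyl in place of nitro on an aromatic carbon. No step between measured compounds matches this change, so nothing shown here sets its size. The three measured numbers sit close together, and compound 4 is expected to stay in the same region, with a step from compound 2 that is expected to be small and perhaps not beyond the scatter, a 1.4-fold lower number from compound 2 to compound 4 (0.14 log units; within the scatter). Compound 4 is therefore estimated at 900 nM, with a range from 300 nM to 3000 nM.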

Compound 4, inhibition constant: 234 nM
The estimate for compound 4 lay 3.8-fold (0.59 log units) above the measured number, and the stated range ends above it.
By their numbers in this assay, from the lowest: compound 4; then compounds 3, 2 and 1 (each within the scatter of the next, the first and the last beyond it).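

In this assay, among these compounds, the earlier compounds gave numbers that could not be ordered, so they showed no sensitivity to any structural feature. Here, methyl in place of nitro on an aromatic carbon, ortho to a large group, gives a 5.3-fold lower number from compound 2 to compound 4 (0.72 log units; beyond the scatter), the first step beyond the scatter and so the first sign that the group at this place matters. 2-Methylphenyl in place of pyridin-4-yl on an aromatic carbon likewise gives a 6.2-fold lower number from compound 1 to compound 4 (0.79 log units; beyond the scatter), which points the same way. Nothing shown gives a reason for either step. The compounds shown leave open how the ether-linked compound with no group at this place compares, and so whether methyl strengthens binding, nitro weakens it, or both. They also leave open whether chlorine, methoxy or an amine at this place would behave like methyl or like nitro.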